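A few compounds are considered here, and "the series" means these few. Any claim that something is new, unique, unknown or untested is made for them only; others in the source may bear on it.

Of the compounds shown here, three of a shared core have been measured in a functional assay on Jurkat cells (Homo sapiens) for inhibition, read by CCK-8 assay, with a stated time of 48 h; a higher number here means a weaker inhibitor of growth, a lower number a stronger inhibitor of growth. Compound 1 `Cc1ccccc1Nc1nc(Nc2ccc(N3CCCCC3)cn2)ncc1Cl` gives only a limit of the assay, > 100000 nM. Compound 2 `Cc1ccccc1Nc1nc(Nc2ccc(N3CCN(C)CC3)cc2)ncc1Cl` gives a number, 13700 nM. Compound 3 `CN1CCN(c2ccc(Nc3ncc(Cl)c(NCc4ccccc4)n3)nc2)CC1` also gives only a limit, > 100000 nM, so its true value is not known, a situation described by the limit of > 100000 nM in this assay, at which 2 of the 3 values shown sit. Compound 4 `CC(C)c1ccc(Nc2nc(Nc3ccc(N4CCN(C)CC4)cn3)ncc2Cl)cc1` has not been measured. Its change from compound 3 is 4-isopropylphenyl in place of benzyl on a nitrogen on an aromatic ring. Compound 2, which carries an aryl rather than a benzyl group on that nitrogen, gives a number where compound 3 gives a limit, so a step toward stronger inhibition is expected from compound 3 to compound 4, an at least 8.3-fold lower number from compound 3 to compound 4 (0.92 log units; beyond the scatter). Compound 4 is thus estimated at 12000 nM, between 2500 nM and 60000 nM.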

Compound 4, concentration for 50% growth inhibition: 7530 nM
The estimate for compound 4 lay 1.6-fold (0.20 log units) above the measured number, within the range that was stated.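

With the rest of the molecule unchanged, 4-isopropylphenyl in place of benzyl on this nitrogen gives an at least 13-fold lower number from compound 3 to compound 4 (1.12 log units; beyond the scatter) in this assay. Going by these compounds alone, the earlier compounds differ from one another in more than one place, so this is the first direct reading of this change. Compound 3 gives only a limit, so the true step could be larger: the limit of > 100000 nM in this assay, at which 2 of the 4 values shown sit.

The compounds shown leave open whether the step comes from replacing benzyl with an aryl group or from the isopropyl group itself. A plain phenyl group on this nitrogen would separate the two.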